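Solubility in phosphate buffer: from compound 1 to compound 3

This account rests on a few compounds, and the source may have more. Where it says the series, first, only, none or still open, it means among the compounds named here.

Compound 1 `CN(C)C(=O)c1cc(-c2cnc(NCc3c(F)ccc4c3CCO4)c3cn[nH]c(=O)c23)n(C)n1`: 3000 nM
Compound 2 `O=C(Nc1ccccc1)c1cnc(NCc2c(F)ccc3c2CCO3)n2cnnc12`: < 1000 nM

Two compounds share the measured ground here. In a physicochemical assay for solubility, read by LC-MS, in phosphate buffer, with a stated time of 24 h, at pH 7.4 (on this read-out lower numbers stand for lower solubility and higher numbers for higher solubility), compound 1 gives 3000 nM, and that is the only number shown. For compound 2 this assay reports < 1000 nM, which is a limit of the assay and not a number (the limit of < 1000 nM in this assay, at which 1 of the 2 values shown sits).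

Compound 3 `Cc1nn(C)cc1-c1cnc(NCc2c(F)ccc3c2CCO3)c2cn[nH]c(=O)c12` has not been measured in this assay. It differs from compound 1 in one place (1,3-dimethyl-1H-pyrazol-4-yl in place of 3-(dimethylcarbamoyl)-1-methyl-1H-pyrazol-5-yl on an aromatic carbon). Compound 1 thus stands as the sole numeric anchor, and no step between measured compounds is shown.

The expected step from compound 1 to compound 3 is a modest fall, a 2.0-fold lower number from compound 1 to compound 3 (0.30 log units; within the scatter), within reach of the scatter. Compound 3 is estimated at 1500 nM in this assay, between 500 nM and 5000 nM.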

Compound 3, solubility: 9000 nM
The estimate for compound 3 lay 6.0-fold (0.78 log units) below the measured number, outside the stated range (above it).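

With a number now on each side of the change, the read-out in this assay is seen to respond to the group on this aromatic carbon: 1,3-dimethyl-1H-pyrazol-4-yl in place of 3-(dimethylcarbamoyl)-1-methyl-1H-pyrazol-5-yl gives a 3.0-fold higher number from compound 1 to compound 3 (0.48 log units; beyond the scatter) at this site. Before this, compound 1 stood as the only numeric anchor, with no step to read at any position. Nothing measured here accounts for the size or direction of this step.

The two groups differ both in the dimethylcarbamoyl and in the way their five-membered ring is joined to the core, and this single step does not separate the two. On these data alone, whether a morpholine or a carboxylic acid on this aromatic carbon would carry the number further in either direction remains open.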